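Methylamino to dimethylamino: compound 2 to compound 4

This account rests on a few compounds, and the source may have more. Where it says the series, first, only, none or still open, it means among the compounds named here.

In a functional assay on HCT-116 cells (Homo sapiens) for cytotoxicity, read by scintillation counting and thymidine incorporation, with a stated time of 72 h (a higher number here means a weaker inhibitor, a lower number a stronger inhibitor), compound 2 (`CCOc1cc(C(=CC#N)c2ccc(NC)cc2)ccc1OC`) gives 55 nM and compound 1 (`CCOc1cc(C(=CC#N)c2cc(OC)cc(OC)c2)ccc1OC`) gives 34 nM as its value, so the two stand within the scatter of each other. In this assay compound 3 (`COc1cc(OC)cc(C(=Cc2ccccc2)c2ccc(OC)c(O)c2)c1`) gives only a limit, > 10000 nM and no number. Compound 4 (`CCOc1cc(C(=CC#N)c2ccc(N(C)C)cc2)ccc1OC`) carries one change against compound 2: methyl in place of hydrogen on a nitrogen on an aromatic ring with methyl in place of hydrogen on a nitrogen on an aromatic ring. Within the data shown here, no measured pair shows this change, so the step expected in this assay is none beyond the scatter. The expected step is a 1.1-fold lower number from compound 2 to compound 4 (0.04 log units; within the scatter) on this reading. The estimated value for compound 4 is 50 nM with an expected range from 15 nM to 250 nM around it.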

Compound 4, half-maximal inhibitory concentration: 31 nM
The estimate for compound 4 lay 1.6-fold (0.21 log units) above the measured number, and the stated range covers the measured number.
By their numbers in this assay, from the lowest: compounds 4, 1 and 2 (each within the scatter of the next). At a limit, above all of these: compound 3.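

In this assay, among these compounds, methyl in place of hydrogen on the nitrogen gives a 1.8-fold lower number from compound 2 to compound 4 (0.25 log units; within the scatter), the first measured pair for this change. This position therefore accepts either methylamino or dimethylamino, with no difference beyond the scatter between compound 2 and compound 4. Nothing measured here bears on the reason for this outcome. Going by these compounds, whether a primary amine or a diethylamino group at this position would stay within the scatter of these values remains open. On these data alone, an acetamide on this nitrogen is equally open.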